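Swapping bromo for pyridin-4-yl on a potent indole amide

This account rests on a few compounds, and the source may have more. Where it says the series, first, only, none or still open, it means among the compounds named here.

Measured compounds and their results:
- Compound 1, `COc1ccccc1N1CCN(C(=O)CCc2c(-c3ccc(Cl)cc3)[nH]c3cccc(Cl)c23)CC1`: 950 nM
- Compound 2, `COc1ccccc1N1CCN(C(=O)CCc2c(-c3ccc(Cl)cc3)[nH]c3cc(Cl)cc(Cl)c23)CC1`: 570 nM
- Compound 3, `Cn1c(-c2ccc(Cl)cc2)c(CCC(=O)N2CCC(O)(Cc3ccccc3)CC2)c2cc(Br)ccc21`: 0.22 nM

These three compounds were tested in an assay on CHO cells for displacement of a labelled ligand from Substance-P receptor (Homo sapiens); a lower number here means a stronger inhibitor, a higher number a weaker inhibitor. Among the compounds with values here, compound 1 gives 950 nM and compound 2 gives 570 nM; the only measured step, a 1.7-fold lower number from compound 1 to compound 2 (0.22 log units; within the scatter), stays within the scatter. Compound 3 is the most potent of the three by a wide margin: in this assay compound 3 gives 0.22 nM, and its gaps to compound 2 and to compound 1 are far beyond the scatter.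

Compound 4, `Cn1c(-c2ccc(Cl)cc2)c(CCC(=O)N2CCC(O)(Cc3ccccc3)CC2)c2cc(-c3ccncc3)ccc21`, has not yet been measured. It differs from compound 3 in one place: pyridin-4-yl in place of bromo on an aromatic carbon. Within the data shown here, no measured step matches this change. Among the measured compounds shown here, the only step available, from compound 1 to compound 2, also exchanges one small group for another on an aromatic carbon and stayed within the scatter, but it involves chloro for hydrogen rather than a six-membered aromatic ring for bromo, so it offers only weak guidance. The expectation is therefore a modest change at most, with a slight lean toward a higher number, as a 2.7-fold higher number from compound 3 to compound 4 (0.44 log units; beyond the scatter). Compound 4 is estimated at 0.6 nM, with a likely range from 0.1 nM to 4 nM.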

Compound 4, half-maximal inhibitory concentration: 5.5 nM
The estimate for compound 4 lay 9.2-fold (0.96 log units) below the measured number, outside the stated range (above it).
By their numbers in this assay, from the lowest: compound 3; then compound 4; then compounds 2 and 1 (each within the scatter of the next).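

In this assay, replacing bromo with pyridin-4-yl on this aromatic carbon gives a 25-fold higher number from compound 3 to compound 4 (1.40 log units; beyond the scatter), so what sits at this place on the six-membered ring of carbon only can change the result by a wide margin. Within the data shown here, the only earlier step, a 1.7-fold lower number from compound 1 to compound 2 (0.22 log units; within the scatter), put chloro in place of hydrogen and stayed within the scatter, so it gave no sign of a shift this large; the new result also shows that a six-membered aromatic ring can sit at this place while compound 4 still gives 5.5 nM in the same assay. Nothing available here explains why the number rose.

The compounds shown do not separate the effect of adding a ring from that of the ring nitrogen, a question that phenyl or pyridin-3-yl at this same place could address. They also leave open how other replacements for bromo would compare, such as a methoxy group, a nitrile or an amine, and whether any of them would keep the number close to that of the bromo compound.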